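This account rests on a few compounds, and the source may have more. Where it says the series, first, only, none or still open, it means among the compounds named here.

Measured compounds:
- compound 1, `CC1(C)CC(NC(=S)Nc2ccc([N+](=O)[O-])cc2)c2cc(Br)ccc2O1`: 5000 nM
- compound 2, `CC1(C)CC(NC(=S)Nc2ccc([N+](=O)[O-])cc2)c2cc(Cl)ccc2O1`: 4000 nM
- compound 3, `CC1(C)CC(NC(=S)NCc2ccccc2)c2cc(Br)ccc2O1`: 54000 nM

All three were tested in a functional assay on T98G cells (Homo sapiens) for inhibition, read by MTT assay, with a stated time of 72 h; on this read-out higher numbers stand for weaker inhibition and lower numbers for stronger inhibition. Compound 1 and compound 2 share one core and differ in a single spot: chloro in place of bromo on an aromatic carbon. That change gave a 1.3-fold lower number from compound 1 to compound 2 (0.10 log units; within the scatter), so the two numbers cannot be told apart. Compound 3 carries a different group on the thiourea; the difference between its core and the core of compound 1 is not broken down here. In this assay compound 3 gives a higher number than compound 1 and compound 2, which stands for weaker inhibition.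

Compound 4, `CC1(C)CC(NC(=S)NCc2ccccc2)c2cc(Cl)ccc2O1`, has not been measured. It differs from compound 3 as chloro in place of bromo on an aromatic carbon. Within the data shown here, this is the same change as the one from compound 1 to compound 2, at the same place on the ring. Among the measured compounds shown here, because that change gave a 1.3-fold lower number from compound 1 to compound 2 (0.10 log units; within the scatter), the step from compound 3 to compound 4 is expected to be small as well, about a 1.2-fold lower number from compound 3 to compound 4 (0.08 log units; within the scatter), resting on the one measured pair alone. Compound 4 is therefore estimated to give about 45000 nM in this assay, most likely between 20000 nM and 110000 nM.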

Compound 4, half-maximal inhibitory concentration: 99000 nM
The estimate for compound 4 lay 2.2-fold (0.34 log units) below the measured number; the measured number falls inside the stated range.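

In this assay, putting chloro in place of bromo on the core of compound 3 gave a 1.8-fold higher number from compound 3 to compound 4 (0.26 log units; within the scatter), so this step, like the earlier one, is too small to separate from the ordinary variation between repeated measurements. Set side by side, the two steps agree as far as such data can tell, and the change behaves alike on both cores: the same change on two cores in this assay, a 1.3-fold lower number (0.10 log units; within the scatter) from compound 1 to compound 2 and a 1.8-fold higher number (0.26 log units; within the scatter) from compound 3 to compound 4, 2.3-fold (0.36 log units) apart, within the scatter of two such steps. Among these compounds, this supports carrying the swap from one of these cores to the other with little expected effect on the number, but it rests on only two pairs, and it shows neither a real direction for the change nor that the same would hold on any other core.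

The compounds shown carry only bromo or chloro at this place on the ring, so it remains open what fluoro, a methoxy group or an amine would do there. They also leave open how far the number depends on the group on the thiourea, for example with a carboxylic acid on the aromatic ring of that group or a longer chain in its place.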